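The compounds below may be only part of what the source reports. "The series", "measured", "known", "first", "only" and "open" are said of these compounds alone.

Measured so far:
- compound 1, `c1ccc(-c2ccccc2OCc2c[nH]cn2)cc1`: 15.9 nM
- compound 2, `c1ccc(-c2ccno2)c(OCC2=NCCN2)c1`: 6.31 nM

In a functional assay for activation of Alpha-1A adrenergic receptor (Homo sapiens) (a lower number here means that less compound is needed, a higher number that more compound is needed for the effect), compound 2 gives the lowest of the two numbers, and compound 1 sits at a higher number, beyond the scatter. Compound 3, `c1ccc(-c2ccno2)c(OCc2c[nH]cn2)c1`, is the next step: a group of 5 heavy atoms (3 carbon, 2 nitrogen; one five-membered aromatic ring with 2 hetero atoms) in place of a group of 5 heavy atoms (3 carbon, 2 nitrogen; one five-membered non-aromatic ring with 2 hetero atoms), on a saturated chain carbon bound to an oxygen on an aromatic ring. Going by the values given here, with only two measured compounds there is no step of this exact kind to lean on. Compound 1, which also carries a 1H-imidazol-4-yl group, gives 15.9 nM in this assay, so for compound 3 a modest rise in the number is expected, a 3.2-fold higher number from compound 2 to compound 3 (0.50 log units; beyond the scatter). Compound 3 is estimated at 20 nM, with a range from 5 nM to 80 nM.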

Compound 3, half-maximal effective concentration: 158 nM
The estimate for compound 3 lay 7.9-fold (0.90 log units) below the measured number; measured number outside the range, above it.
By their numbers in this assay, from the lowest: compound 2; then compound 1; then compound 3.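

In this assay, swapping the group on the saturated chain carbon bound to an oxygen on an aromatic ring has a large effect: 1H-imidazol-4-yl in place of the non-aromatic five-membered ring gives a 25-fold higher number from compound 2 to compound 3 (1.40 log units; beyond the scatter) with the rest of the molecule unchanged. A second position also counts, as 1,2-oxazol-5-yl in place of phenyl on an aromatic carbon gives a 9.9-fold higher number from compound 1 to compound 3 (1.00 log units; beyond the scatter) for the same chain and imidazole. Nothing available explains either step.

Still open, from the compounds shown here alone, is how the non-aromatic ring behaves alongside phenyl. Also open, going by these compounds, is whether a simple amine or a longer chain could replace either ring on that carbon.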